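Fluoro in place of ethoxy: notes on the series

The source may report more compounds than this note shows. Statements on the series, on what has been measured and on what is new or still open speak of the compounds shown alone.

Measured so far in a functional assay on SGC-7901 cells (Homo sapiens) for antiproliferative activity, read by MTT assay, with a stated time of 48 h; on this read-out lower numbers stand for stronger inhibition and higher numbers for weaker inhibition:
compound 1 `Cc1ccccc1-c1nnc(SCc2ccc(Cl)nc2)o1` (8.51 ug/mL)
compound 2 `Cc1ccc(-c2nnc(SCc3ccc(Cl)nc3)o2)cc1` (3.62 ug/mL)
compound 3 `CCOc1ccc(-c2nnc(SCc3ccc(Cl)nc3)o2)cc1` (4.97 ug/mL)

Compound 3 (4.97 ug/mL) sits within the scatter of both compound 1 and compound 2, although those two are separated by more than the scatter. The next case is compound 4 `Fc1ccc(-c2nnc(SCc3ccc(Cl)nc3)o2)cc1`, which carries fluoro in place of ethoxy on an aromatic carbon, para to a large group (fluoro in place of ethoxy on an aromatic carbon). The closest evidence is the step of a 1.4-fold higher number from compound 2 to compound 3 (0.14 log units; within the scatter), an exchange of ethoxy and methyl at the same place, and it stayed within the scatter. The step of a 2.4-fold lower number from compound 1 to compound 2 (0.37 log units; beyond the scatter) is modest and moves the methyl group, which the present change does not do. For the measured compounds named here, no fluoro compound has been measured, so the comparison rests on a single exchange. No step beyond the scatter is therefore expected in this assay. The expected step is a 1.1-fold lower number from compound 3 to compound 4 (0.04 log units; within the scatter). The estimate for compound 4 is 4.5 ug/mL, with an expected range of 2 ug/mL to 10 ug/mL.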

Compound 4, half-maximal inhibitory concentration: 3.67 ug/mL
Compound 4: the middle estimate sits 1.2-fold (0.09 log units) above what was measured; measured number inside the range.
By their numbers in this assay, from the lowest: compounds 2, 4, 3 and 1 (each within the scatter of the next, the first and the last beyond it).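

In this assay fluoro joins ethoxy and methyl at the aromatic carbon para to a large group, and the three cannot be told apart: both a 1.4-fold lower number from compound 3 to compound 4 (0.13 log units; within the scatter) and a 1.0-fold higher number from compound 2 to compound 4 (0.01 log units; within the scatter) stay within the scatter, even though fluoro has 1 heavy atom where ethoxy has 3. The step of a 2.3-fold lower number from compound 1 to compound 4 (0.37 log units; beyond the scatter) sets compound 1 apart from compound 4 as well as from compound 2, while compound 3 remains within the scatter of compound 1. No measurement here explains why these groups read alike.

An amine, a carboxylic acid or a longer chain such as butoxy at this place could still read differently. A 2-fluorophenyl group would show whether 4-fluorophenyl and 2-methylphenyl differ through the group or through its place.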